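From Cyclohexyl to 3-Nitrophenyl: A Step Not Yet Measured

This account rests on a few compounds, and the source may have more. Where it says the series, first, only, none or still open, it means among the compounds named here.

Three compounds have numbers in a functional assay on KMS-11 cells (Homo sapiens) for antiproliferative activity, read by CellTiter-Glo, with a stated time of 72 h; a lower number here means a stronger inhibitor, a higher number a weaker inhibitor. Compound 1 (`COc1ccc(C(=O)N(Cc2ccncc2)Cc2cccc(OCC3CCN(C(=O)OC(C)(C)C)CC3)c2)cc1`) gives 5100 nM, compound 2 (`COc1ccc(C(=O)N(Cc2ccncc2)Cc2cccc(OCC3CCCCC3)c2)cc1`) gives 19700 nM, and compound 3 (`O=C(c1ccc(Cl)cc1)N(Cc1ccncc1)Cc1cccc(OCCc2ccc(F)cc2)c1`) gives 13100 nM. Compound 2 thus stands within the scatter of compound 3, while compound 1 has a lower number than compound 2 by more than the scatter.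

Compound 4 (`COc1ccc(C(=O)N(Cc2ccncc2)Cc2cccc(OCc3cccc([N+](=O)[O-])c3)c2)cc1`) has not yet been measured. It differs from compound 2 in one place, with 3-nitrophenyl in place of cyclohexyl on a saturated chain carbon bound to an oxygen on an aromatic ring. Among the measured compounds shown here, no measured pair isolates this change, so its size cannot be read directly from the data. For the measured compounds named here, the only guide is the range of the series, and compound 1 at 5100 nM and compound 3 at 13100 nM each differ from compound 2 in more than this one place. In this assay a small step toward a lower number is expected, probably not beyond the scatter. The estimated change is a 1.8-fold lower number from compound 2 to compound 4 (0.25 log units; within the scatter). For compound 4 the estimated value is 11000 nM, with an expected range of 4500 nM to 25000 nM.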

Compound 4, half-maximal inhibitory concentration: 19600 nM
Beside the measured number, compound 4's estimate is 1.8-fold (0.25 log units) below it, within the range that was stated.
By their numbers in this assay, from the lowest: compound 1; then compounds 3, 4 and 2 (each within the scatter of the next).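

In this assay, the step of a 1.0-fold lower number from compound 2 to compound 4 (0.00 log units; within the scatter) is the first among these compounds to isolate a single change at this position, on a saturated chain carbon bound to an oxygen on an aromatic ring. It shows that, on the core of compound 2, this place accepts 3-nitrophenyl in place of cyclohexyl with no change beyond the scatter, even though the entering group has an aromatic ring, 9 heavy atoms against 6, and 2 hydrogen-bond acceptors where cyclohexyl has none. Nothing available bears on why these two groups read alike in this assay.

The compounds shown leave open whether the nitro group and the aromatic ring each matter on their own, since a plain benzyl group, a 3-aminobenzyl group or a 3-carboxybenzyl group at this place would separate the ring from its substituent. They also leave open whether the same swap would read alike with a longer chain, such as an ethylene link, between the oxygen and the ring, or on a core other than that of compound 2.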